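This account rests on a few compounds, and the source may have more. Where it says the series, first, only, none or still open, it means among the compounds named here.

Working notes on the series.

The shared core is that of compound 1 `Cc1nc(-c2ccc(Cl)cc2)c(CC(=O)O)s1`, which in an in vitro functional assay on HEK285-7 cells for antagonist activity at prostaglandin D2 receptor 2 (Homo sapiens), read by BRET and beta-arrestin recruitment (on this read-out lower numbers stand for stronger inhibition and higher numbers for weaker inhibition), gives 41000 nM. Compound 2 `O=C(O)Cc1sc(C(c2ccc(F)cc2)c2ccc(F)cc2)nc1-c1cc(F)cc(F)c1` carries 3,5-difluorophenyl on the aromatic carbon and the large bis(4-fluorophenyl)methyl group; in this assay compound 2 gives 340 nM. Compound 3 `O=C(O)Cc1sc(C(c2ccc(F)cc2)c2ccc(F)cc2)nc1-c1ccnc(N2CCCC2)c1` carries 2-(pyrrolidin-1-yl)pyridin-4-yl in that place. For compound 3 only a limit of this assay is available, > 100000 nM, which is the limit of > 100000 nM in this assay, at which 1 of the 3 values shown sits; no number stands for it. The step of an at least 290-fold higher number from compound 2 to compound 3 (2.46 log units; beyond the scatter) is thus a large loss whose true size is open at the upper end.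

Compound 4 `O=C(O)Cc1sc(C(c2ccc(F)cc2)c2ccc(F)cc2)nc1-c1cc(F)nc(F)c1` is the next point: 2,6-difluoropyridin-4-yl in place of 2-(pyrrolidin-1-yl)pyridin-4-yl on an aromatic carbon. Going by the values given here, the only measured step that bears on this change is an at least 290-fold higher number from compound 2 to compound 3 (2.46 log units; beyond the scatter), and compound 4 is structurally the nearer relative of compound 2, the two rings differing in a ring nitrogen alone. The expectation in this assay is therefore a large step to a lower number, an at least 66-fold lower number from compound 3 to compound 4 (1.82 log units; beyond the scatter), recovering most of what was lost in an at least 290-fold higher number from compound 2 to compound 3 (2.46 log units; beyond the scatter) but not necessarily all of it. Compound 4 is estimated at 1500 nM, with a range from 300 nM to 10000 nM.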

Compound 4, half-maximal inhibitory concentration: 110 nM
Compound 4: middle estimate off by 14-fold (1.13 log units), on the high side; the measured number lies below the stated range.
By their numbers in this assay, from the lowest: compound 4; then compound 2; then compound 1. At a limit, above all of these: compound 3.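

In this assay, a ring nitrogen is accepted on the aromatic carbon next to the ring nitrogen of the five-membered ring: 2,6-difluoropyridin-4-yl in place of 3,5-difluorophenyl gives a 3.1-fold lower number from compound 2 to compound 4 (0.49 log units; beyond the scatter), so the pyridine ring alone does not account for the loss seen with compound 3. Both pyridin-4-yl groups sit in the same place, and exchanging the one with pyrrolidin-1-yl for the difluoro one gives an at least 900-fold lower number from compound 3 to compound 4 (2.95 log units; beyond the scatter), which ties the loss to the substitution on the pyridine ring and not to the ring itself. Compound 3 stands at a limit, so the size of this step stays open at the upper end: the limit of > 100000 nM in this assay, at which 1 of the 4 values shown sits.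

The compounds shown do not tell whether the loss follows any amine on the pyridine ring or only the pyrrolidine ring, which a pyridin-4-yl carrying a dimethylamino or a methoxy group would address. On these data alone, whether 2,6-difluoropyridin-4-yl holds its number when the bis(4-fluorophenyl)methyl group gives way to the methyl of compound 1 also stays open.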